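Two Chlorines Replace a Trifluoromethyl on the Amide Nitrogen

The source may hold more compounds than are shown below. What is called first, only, known or untested is meant among the compounds shown, and "the series" means these compounds.

Three compounds share one core and differ only in the phenyl group attached to an amide-type nitrogen. Compound 1 `COc1cc2cc(Oc3ccc(NC(=O)Nc4ccc(C)cc4)cc3)c(C)nc2cc1OC` carries a 4-methylphenyl there, and in a functional assay on HCC 2998 cells (Homo sapiens) for inhibition, read by sulforhodamine B assay, with a stated time of 48 h, tested at 10 uM (on this read-out higher numbers stand for a weaker effect at the one concentration tested and lower numbers for a stronger effect), compound 1 gives 104%. Compound 2 `COc1cc2cc(Oc3ccc(NC(=O)Nc4ccc(C(F)(F)F)cc4)cc3)c(C)nc2cc1OC` carries a 4-(trifluoromethyl)phenyl, and compound 2 gives 94.8%. Compound 3 `COc1cc2cc(Oc3ccc(NC(=O)Nc4cccc(C(F)(F)F)c4)cc3)c(C)nc2cc1OC` carries a 3-(trifluoromethyl)phenyl, and compound 3 gives 25.4%, the lowest of the three numbers, so compound 3 shows the strongest effect of the set.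

The steps show where the numbers move. a number 9.2 percentage points lower from compound 1 to compound 2 (within the scatter) stays within the scatter. a number 78.6 percentage points lower from compound 1 to compound 3 (beyond the scatter) and a number 69.4 percentage points lower from compound 2 to compound 3 (beyond the scatter) are both large, so the switch to the 3-(trifluoromethyl)phenyl is what brings the number down.

Compound 4 `COc1cc2cc(Oc3ccc(NC(=O)Nc4ccc(Cl)c(Cl)c4)cc3)c(C)nc2cc1OC` is the next step: 3,4-dichlorophenyl in place of 3-(trifluoromethyl)phenyl on an amide-type nitrogen. For the measured compounds named here, no measured step tells how chlorine compares with trifluoromethyl at this place. The strong effect of compound 3 rests on its 3-(trifluoromethyl)phenyl, shown by a number 78.6 percentage points lower from compound 1 to compound 3 (beyond the scatter), and the 3,4-dichlorophenyl of compound 4 is a different group, so some loss is possible but a large one is not expected. The step of a number 9.6 percentage points higher from compound 3 to compound 4 (within the scatter) is therefore expected to be modest. Compound 4 is estimated at 35%, within a range from 10% to 75%.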

Compound 4, a percentage reported as activity, at one concentration (the size of the read-out at that concentration, not a potency): 37.6%
Beside the measured number, compound 4's estimate is 2.6 percentage points below it; the range from low to high includes it.
By their numbers in this assay, from the lowest: compound 3; then compound 4; then compounds 2 and 1 (each within the scatter of the next).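

In this assay, the step of a number 12.2 percentage points higher from compound 3 to compound 4 (beyond the scatter) is modest, so the strong effect does not belong to the 3-(trifluoromethyl)phenyl alone: the 3,4-dichlorophenyl, which holds chlorine and no fluorine, keeps most of it. For the compounds shown here, the steps of a number 57.2 percentage points lower from compound 2 to compound 4 (beyond the scatter) and a number 66.4 percentage points lower from compound 1 to compound 4 (beyond the scatter) are both large, so in these four compounds the two phenyl groups with a 3 in their names give the low numbers and the two named with a 4 alone do not, and no compound here goes against this; the 4 in 3,4-dichlorophenyl also shows that a group named at 4 does not by itself cancel the effect. No measurement on hand offers a cause for any of these differences.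

The compounds shown leave open whether a single chlorine, as in a 3-chlorophenyl, would be enough or whether the second chlorine of compound 4 is needed. They also leave open how far the effect reaches beyond halogen-bearing groups, for instance with a 3-methoxyphenyl or a 3-aminophenyl on the same amide-type nitrogen.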